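A few compounds are considered here, and "the series" means these few. Any claim that something is new, unique, unknown or untested is made for them only; others in the source may bear on it.

Within the data shown here, in an ADME assay (liver) for metabolic stability, with Liver microsome (Rattus norvegicus) as the target, using microsomes and NADPH, with a stated time of 30 min, tested at 1 uM (on this read-out lower numbers stand for slow clearance and higher numbers for fast clearance), compound 1 `Nc1ccc(S(=O)(=O)N2CCN(c3ncc(C(O)(C(F)(F)F)C(F)(F)F)cc3-c3ccncc3)CC2)cn1` gives 31 mL.min-1.g-1 and compound 2 `Cc1nc2cc(-c3cc(C(O)(C(F)(F)F)C(F)(F)F)cnc3N3CCN(S(=O)(=O)c4ccc(N)nc4)CC3)ccc2o1` gives 99 mL.min-1.g-1 as the higher of the two numbers so far. Among the measured compounds shown here, the one measured step, modest and beyond the scatter, is a 3.2-fold higher number from compound 1 to compound 2 (0.50 log units; beyond the scatter) with 2-methyl-1,3-benzoxazol-5-yl in place of pyridin-4-yl on an aromatic carbon. Compound 3 `Nc1ccc(S(=O)(=O)N2CCN(c3ncc(C(O)(C(F)(F)F)C(F)(F)F)cc3-c3cc4ccccc4[nH]3)CC2)cn1` carries the change 1H-indol-2-yl in place of 2-methyl-1,3-benzoxazol-5-yl on an aromatic carbon at that same place, with 1H-indol-2-yl in place of 2-methyl-1,3-benzoxazol-5-yl. Both of these groups hold one five-membered aromatic ring and one six-membered aromatic ring of carbon only. For the measured compounds named here, no measured step exchanges two such groups, so the data give no direct guide. The expectation therefore rests on compound 2 at 99 mL.min-1.g-1 as the nearest measured case, while compound 1 at 31 mL.min-1.g-1 marks the lower side of the range. A small move to a slightly lower number is expected, with a 1.2-fold lower number from compound 2 to compound 3 (0.07 log units; within the scatter) estimated to stay within the scatter. Compound 3 is estimated at 85 mL.min-1.g-1 with an expected range from 40 mL.min-1.g-1 to 170 mL.min-1.g-1 in this assay for now.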

Compound 3, intrinsic clearance in microsomes: 146 mL.min-1.g-1
The estimate for compound 3 lay 1.7-fold (0.23 log units) below the measured number; low and high end bracket the measured number.
By their numbers in this assay, from the lowest: compound 1; then compounds 2 and 3 (each within the scatter of the next).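

At the aromatic carbon ortho to a large group, this assay does not separate 1H-indol-2-yl from 2-methyl-1,3-benzoxazol-5-yl, with a 1.5-fold higher number from compound 2 to compound 3 (0.17 log units; within the scatter) even though the two groups differ in their hetero atoms and in their hydrogen-bond donors and acceptors. Set against pyridin-4-yl, 1H-indol-2-yl gives a 4.7-fold higher number from compound 1 to compound 3 (0.67 log units; beyond the scatter) and so joins 2-methyl-1,3-benzoxazol-5-yl, which gave a 3.2-fold higher number from compound 1 to compound 2 (0.50 log units; beyond the scatter) in the same comparison; among these three compounds, both groups holding a five-membered and a six-membered aromatic ring stand beyond the scatter from pyridin-4-yl, and no compound shown goes against this. Nothing at hand bears on what lies behind these numbers.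

On these data alone, it remains open whether the single six-membered ring of phenyl or a second ring is what separates compound 1 from compound 2 and compound 3 at this position. Also open, as far as these compounds go, is how the number would respond to an amine or a carboxylic acid on the group at this position, or to a saturated ring such as morpholine in its place.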